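A carbonyl swap on a compound at the limit

This account rests on a few compounds, and the source may have more. Where it says the series, first, only, none or still open, it means among the compounds named here.

Measured in a functional assay on cells (Platelet, Homo sapiens) for inhibition; a higher number here means a weaker inhibitor, a lower number a stronger inhibitor:
compound 1 `CCOC(=O)c1ccc(-c2nn(Cc3ccncc3)c3ccccc23)cc1`: > 10000 nM
compound 2 `CCOC(=O)c1ccc(-c2nn(C(C)C)c3ccccc23)cc1`: > 10000 nM
compound 3 `COC(=O)c1ccc(-c2nn(Cc3ccccc3)c3ccccc23)cc1`: > 10000 nM

All three results are limits and not numbers, and the record reads: the limit of > 10000 nM in this assay, at which 3 of the 3 values shown sit. Compound 3 stands at a limit, > 10000 nM.

Compound 4 `CCNC(=O)c1ccc(-c2nn(Cc3ccccc3)c3ccccc23)cc1` keeps the shared core and changes one place: ethylamino in place of methoxy on a carbonyl carbon. This is ethylamino in place of methoxy on a carbonyl carbon.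

Among the compounds with values here, the only measured step, a step that the two limits leave unreadable from compound 1 to compound 2, lies on an aromatic nitrogen, not on the carbonyl, and gives no usable size. No change beyond the scatter is therefore expected in this assay, in either direction, and another limit is the likeliest report. The expected step is a step that the limit leaves unreadable from compound 3 to compound 4. For compound 4 the estimate is 12000 nM, with an expected range of 3000 nM to 40000 nM.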

Compound 4, half-maximal inhibitory concentration: > 10000 nM
Compound 4 was reported as a limit; the forecaster's own chance of this, stated with the estimate: 85%; the middle value is on the limit's open side.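

Compound 3 and compound 4 are both reported only as limits in this assay, so no step between them can be read: the limit of > 10000 nM in this assay, at which 4 of the 4 values shown sit.

The compounds shown leave open how strongly any of them inhibits, and whether a change on the carbonyl carbon matters at all.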